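Furan-2-yl to thiophen-2-yl: what to expect

This account rests on a few compounds, and the source may have more. Where it says the series, first, only, none or still open, it means among the compounds named here.

Measured in a functional assay on HOS cells (Homo sapiens) for inhibition, with a stated time of 72 h; a higher number here means a weaker inhibitor, a lower number a stronger inhibitor:
Compound 1 `NC1CCC(Nc2nc(NCc3ccc(-c4ccccc4)cc3)c3ncn(C4CCCC4)c3n2)CC1`: 290 nM
Compound 2 `NC1CCC(Nc2nc(NCc3ccc(-c4cccc(F)c4)nc3)c3ncn(C4CCCC4)c3n2)CC1`: 44 nM
Compound 3 `NC1CCC(Nc2nc(NCc3ccc(-c4ccco4)nc3)c3ncn(C4CCCC4)c3n2)CC1`: 44 nM

Compound 3 shares the lowest number of the three with compound 2, so it is among the stronger inhibitors measured here, and compound 1 stands clearly higher. The next structure, compound 4 `NC1CCC(Nc2nc(NCc3ccc(-c4cccs4)nc3)c3ncn(C4CCCC4)c3n2)CC1`, has thiophen-2-yl in place of furan-2-yl on an aromatic carbon.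

Among the compounds with values here, no compound with thiophen-2-yl has been measured yet, so two steps must serve as a guide. The closer one exchanges 3-fluorophenyl for furan-2-yl on that same carbon, and it gives no change at the digits printed from compound 2 to compound 3 (within the scatter). The other replaces the whole 4-phenylphenyl group, a much larger change, and it gives a 6.6-fold lower number from compound 1 to compound 3 (0.82 log units; beyond the scatter). It therefore says less about this swap of one five-membered ring for another.

On this evidence, no step beyond the scatter is expected in this assay. The expected step is a 1.0-fold higher number from compound 3 to compound 4 (0.01 log units; within the scatter). For compound 4 the estimated value is 45 nM, with an expected range from 20 nM to 110 nM.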

Compound 4, half-maximal inhibitory concentration: 32 nM
Beside the measured number, compound 4's estimate is 1.4-fold (0.15 log units) above it; the range from low to high includes it.
By their numbers in this assay, from the lowest: compounds 4, 2 and 3 (each within the scatter of the next); then compound 1.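

In this assay, exchanging furan-2-yl for thiophen-2-yl, two rings with the same count of heavy atoms that differ in one oxygen against one sulfur, gives a 1.4-fold lower number from compound 3 to compound 4 (0.14 log units; within the scatter) and so leaves the number within the scatter. Thiophen-2-yl likewise gives a 1.4-fold lower number from compound 2 to compound 4 (0.14 log units; within the scatter) against 3-fluorophenyl, so this carbon next to the ring nitrogen has now carried three different aromatic rings with no step beyond the scatter among them. The wider exchange of 4-phenylphenyl for 6-(thiophen-2-yl)pyridin-3-yl gives a 9.1-fold lower number from compound 1 to compound 4 (0.96 log units; beyond the scatter) and lies beyond the scatter, as it did with the furan-2-yl group.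

No supporting measurement is available to explain any of these numbers. Still open, from the compounds shown here alone, is how a non-aromatic group on this same carbon, such as an amine or a morpholine ring, would compare with these aromatic rings.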